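A few compounds are considered here, and "the series" means these few. Any claim that something is new, unique, unknown or untested is made for them only; others in the source may bear on it.

In a functional assay on A549 cells (Homo sapiens) for antiproliferative activity, read by CCK-8 assay, with a stated time of 72 h (a lower number here means a stronger inhibitor of growth, a higher number a weaker inhibitor of growth), compound 1 `CCC1C(=O)N(C)c2cnc(-n3ccc4cc(C(=O)NC(C)C)ccc43)nc2N1c1ccn(C)n1` gives 22000 nM and compound 3 `CCC1C(=O)N(C)c2cnc(-n3ccc4cc(C(=O)NCC(C)C)ccc43)nc2N1c1ccn(C)n1` gives 19200 nM, two values within the scatter of each other. Compound 2 `CCC1C(=O)N(C)c2cnc(-n3ccc4cc(F)ccc43)nc2N1c1ccn(C)n1` is reported as "not active" (no number reported), with no number. Compound 4 `CCC1C(=O)N(C)c2cnc(-n3ccc4cc(C(=O)NC5CCCC5)ccc43)nc2N1c1ccn(C)n1` has not yet been measured. It differs from compound 3 by cyclopentyl in place of isobutyl on an amide-type nitrogen. Going by the values given here, only one measured step bears on this, another swap on that same nitrogen, isobutyl in place of isopropyl. That step, a 1.1-fold lower number from compound 1 to compound 3 (0.06 log units; within the scatter), stayed within the scatter, so no step beyond the scatter is expected here. The expected step is a 1.1-fold lower number from compound 3 to compound 4 (0.03 log units; within the scatter). The estimate for compound 4 is 18000 nM, with an expected range of 8000 nM to 40000 nM.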

Compound 4, concentration for 50% growth inhibition: 39500 nM
Beside the measured number, compound 4's estimate is 2.2-fold (0.34 log units) below it; low and high end bracket the measured number.
By their numbers in this assay, from the lowest: compounds 3, 1 and 4 (each within the scatter of the next, the first and the last beyond it).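

In this assay, going by these compounds alone, cyclopentyl gives the first step on this amide-type nitrogen that goes beyond the scatter, though only a modest one: a 2.1-fold higher number from compound 3 to compound 4 (0.31 log units; beyond the scatter). Against the isopropyl amide the same group gives a 1.8-fold higher number from compound 1 to compound 4 (0.25 log units; within the scatter), so only one of the two comparisons clears the scatter. Nothing measured here accounts for the step. These compounds leave open whether the ring itself matters or only the number of carbons, and an open pentyl chain could help separate the two. On these data alone, how a cyclopropyl ring or a chain ending in an amine would read on this nitrogen also stays open.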